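From compound 1 to compound 4: one arm exchanged

This account rests on a few compounds, and the source may have more. Where it says the series, first, only, none or still open, it means among the compounds named here.

The series is followed in a functional assay on U-87MG ATCC cells (Homo sapiens) for antiproliferative activity, with a stated time of 3 days (on this read-out higher numbers stand for an effect only at larger amounts of compound and lower numbers for an effect already at smaller amounts), and so far offers little to work with. Compound 1 (`Oc1ccc(CN(Cc2ccc(OC(F)(F)F)cc2)Cc2ccc(O)c3ncccc23)c2cccnc12`) has no position on the scale, since its entry reads "not determined" (no result reported) without any number. Compound 2 (`CC(C)(C)OC(=O)N(Cc1cc(C(F)(F)F)cc(C(F)(F)F)c1)Cc1ccc(O)c2ncccc12`) is in the same state, with "not determined" (no result reported) as its entry. Within the data shown here, the only number comes from compound 3 (`Cc1ccc(C(=O)NCc2ccc(O)c3ncccc23)cc1`), which gives 10 uM in this set of results.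

The next compound is compound 4 (`Oc1ccc(CN(Cc2ccc(O)c3ncccc23)Cc2ccc(O)c3ncccc23)c2cccnc12`). The structural change is as follows: 8-hydroxyquinolin-5-yl in place of 4-(trifluoromethoxy)phenyl on a saturated chain carbon bound to an amine nitrogen and, cut one bond further out, it reads 4-(trifluoromethoxy)benzyl to (8-hydroxyquinolin-5-yl)methyl. The entering group already occurs in compound 1 and in compound 3.

Among the measured compounds shown here, no measured step shows what this exchange does, and compound 1 offers no number to count a step from. A modest step toward lower numbers is expected, though this is a working assumption. The only reference for it is compound 3 at 10 uM as the one measured carrier of the (8-hydroxyquinolin-5-yl)methyl group. In this assay compound 4 is expected at 4 uM within an estimated range from 1 uM to 15 uM as a working figure.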

Compound 4, concentration for half-maximal effect: > 10 uM
Compound 4: no number, only a limit; the forecaster's own chance of this, stated with the estimate: 15%; at least 2.5-fold (0.39 log units) between middle value and limit.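

Among these compounds, no step from compound 1 to compound 4 can be read: compound 1 has no number in this assay. Compound 4 gives > 10 uM, which is a limit and not a number. The compounds shown leave open what exchanging 4-(trifluoromethoxy)benzyl for (8-hydroxyquinolin-5-yl)methyl does to this read-out.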